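Adding a Methyl to the Ketone Chain of Compound 3

A few compounds are considered here, and "the series" means these few. Any claim that something is new, unique, unknown or untested is made for them only; others in the source may bear on it.

Measured compounds:
- compound 1, `CC1=C(C(=O)OC(C)(C)C)C(c2cccs2)NC(=O)N1`: 38%
- compound 2, `CC1=C(C(=O)C2CC2)C(c2cccs2)NC(=O)N1`: 1%
- compound 3, `CCCC(=O)C1=C(C)NC(=O)NC1c1cccs1`: 9%

The three measured compounds share one core and differ only in the group on the carbonyl carbon. In an assay on membranes from HEK293 cells for displacement of a labelled ligand from adenosine receptor A2b (Homo sapiens), read by scintillation counting, with a stated time of 30 min, tested at 1 uM (on this read-out higher numbers stand for more inhibition at the one concentration tested (going by the name of the read-out) and lower numbers for less inhibition), compound 1 gives 38%, the highest of the three numbers. Compound 3 stands second highest: its nearest neighbour is compound 2, whose value lies lower but within the scatter, and the furthest is compound 1, whose value lies higher beyond the scatter. The steps tell the same story: a number 37 percentage points lower from compound 1 to compound 2 (beyond the scatter) and a number 29 percentage points lower from compound 1 to compound 3 (beyond the scatter) are both clear falls, while a number 8 percentage points higher from compound 2 to compound 3 (within the scatter) is within the scatter.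

Compound 4, `CC1=C(C(=O)CC(C)C)C(c2cccs2)NC(=O)N1`, differs from compound 3 by methyl in place of hydrogen on a saturated chain carbon bound to two saturated chain carbons. For the measured compounds named here, no measured step tests this exact change; the only step between two carbon chains on the carbonyl, the step from compound 2 to compound 3, was within the scatter. Compound 4 is therefore expected to give about 12%, between 0% and 28%, an estimated step of a number 3 percentage points higher from compound 3 to compound 4 (within the scatter) that stays within the scatter.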

Compound 4, a percentage reported as inhibition, at one concentration (the size of the read-out at that concentration, not a potency): 43%
Compound 4: the middle estimate sits 31 percentage points below what was measured; measured number outside the range, above it.
By their numbers in this assay, from the lowest: compounds 2 and 3 (each within the scatter of the next); then compounds 1 and 4 (each within the scatter of the next).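

In this assay, one methyl on a saturated chain carbon bound to two saturated chain carbons, which turns propyl into isobutyl, gives a number 34 percentage points higher from compound 3 to compound 4 (beyond the scatter), so this position answers strongly to a single added carbon, something the earlier step between two carbon chains did not show. Isobutyl also stands clear of cyclopropyl, with a number 42 percentage points higher from compound 2 to compound 4 (beyond the scatter), while a number 5 percentage points higher from compound 1 to compound 4 (within the scatter) does not separate isobutyl from tert-butoxy, so a carbon chain on the carbonyl can match the tert-butoxy group here. Nothing available explains why this added methyl has so large an effect.

The compounds shown leave open whether a longer chain, such as isopentyl, or an amine at the end of the chain would keep this number. As far as these compounds go, with each compound read at one concentration only, their potencies also remain open.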